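Series notes: compound 2 to compound 4 in cytotoxicity

The compounds below may be only part of what the source reports. "The series", "measured", "known", "first", "only" and "open" are said of these compounds alone.

Three members of the series have numbers in an ADME assay on HEL cells (Homo sapiens) for cytotoxicity; on this read-out higher numbers stand for lower toxicity in this test and lower numbers for higher toxicity in this test. Compound 1 `C/C(=N\NC(=O)COc1cccc2ccccc12)c1ccccc1` gives 20 ug/mL. Compound 2 `O=C(COc1cccc2ccccc12)N/N=C/C=C/c1ccccc1` gives 100 ug/mL, the highest of the three numbers; its nearest neighbour is compound 1, a step beyond the scatter, and its furthest is compound 3 `C/C(=N\NC(=O)COc1cccc2ccccc12)c1ccc(O)cc1`, which gives 11.1 ug/mL. For the measured compounds named here, the only measured step between compounds differing in one place, a 1.8-fold lower number from compound 1 to compound 3 (0.26 log units; within the scatter), concerns a hydroxy group on an aromatic carbon and does not touch the change considered here.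

Compound 4 `O=C(COc1cccc2ccccc12)N/N=C/c1cccc(Cl)c1` awaits measurement. It differs from compound 2 as follows: 3-chlorophenyl in place of 2-phenylethenyl on a carbon with a double bond to nitrogen. Going by the values given here, no measured pair shows this change. Among the compounds with values here, what the data offer is only the pair compound 1 and compound 2: compound 1, which carries a phenyl ring and a methyl on the carbon with a double bond to nitrogen, gives the lower number, and compound 2, which carries 2-phenylethenyl there, gives the higher. Compound 4 carries an aryl ring directly on that carbon, as compound 1 does, so a number below that of compound 2 is expected, the estimated step being a 2.5-fold lower number from compound 2 to compound 4 (0.40 log units; beyond the scatter). Within the data shown here, the estimate for compound 4 is 40 ug/mL, with a range from 12 ug/mL to 120 ug/mL, the uncertainty being wide since no step of this kind has been measured.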

Compound 4, half-maximal cytotoxic concentration: 58.6 ug/mL
For compound 4 the middle estimate is 1.5-fold (0.17 log units) below the measured one, within the range that was stated.
By their numbers in this assay, from the lowest: compounds 3 and 1 (each within the scatter of the next); then compounds 4 and 2 (each within the scatter of the next).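

Position notes: in this assay, 3-chlorophenyl in place of 2-phenylethenyl on a carbon with a double bond to nitrogen gives a 1.7-fold lower number from compound 2 to compound 4 (0.23 log units; within the scatter), the first measured step at this position in the series. The 2-phenylethenyl group, with its double bond outside aromatic rings, can therefore give way to a chlorine-bearing aromatic ring at this place without a read-out change that stands clear of the scatter, so this exchange leaves the number on this read-out unresolved from that of the parent compound. No data on any property of the two groups bear on this result, and the step stands here as an observation without an explanation.

The compounds shown do not separate any contribution of the chlorine from that of replacing the 2-phenylethenyl group, and a single step cannot say whether other aryl groups at this place would behave in the same way. Also open, on these data alone, is how the read-out would respond to a carboxylic acid, an amine or a longer chain in place of 3-chlorophenyl on this carbon.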